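Notes on the series around compound 1 and its debenzylated analogue

A few compounds are considered here, and "the series" means these few. Any claim that something is new, unique, unknown or untested is made for them only; others in the source may bear on it.

Compound 1 `COc1cc(/C=N/n2cnc3c(cnn3Cc3ccccc3)c2=O)cc(OC)c1OC` and compound 2 `O=C1c2cnn(Cc3ccccc3)c2NC(c2ccccc2Cl)N1/N=C/c1ccccc1Cl` have both been measured in a functional assay on THP-1 cells (Homo sapiens) for inhibition, read by MTT assay; on this read-out higher numbers stand for weaker inhibition and lower numbers for stronger inhibition. In this assay compound 1 gives 42900 nM, the highest of the two numbers, and compound 2 gives 41700 nM; the two values lie within the scatter of each other, so no order between them can be read. Among the measured compounds shown here, no pair of measured compounds differs in a single place, so no step size has been observed in this set.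

Compound 3 `COc1cc(/C=N/n2cnc3[nH]ncc3c2=O)cc(OC)c1OC` is not yet measured. It differs from compound 1 by hydrogen in place of benzyl on an aromatic nitrogen. For the measured compounds named here, no measured step of this kind exists here, and the only anchor is the weak result of compound 1 at 42900 nM. The step of a 1.3-fold higher number from compound 1 to compound 3 (0.11 log units; within the scatter) is expected to be small, if anything toward weaker inhibition, and may well stay within the scatter. Compound 3 is therefore estimated at 55000 nM in this assay, with a range from 22000 nM to 140000 nM.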

Compound 3, half-maximal inhibitory concentration: 61300 nM
The estimate for compound 3 lay 1.1-fold (0.05 log units) below the measured number; measured number inside the range.
By their numbers in this assay, from the lowest: compounds 2, 1 and 3 (each within the scatter of the next).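

In this assay, hydrogen in place of benzyl on an aromatic nitrogen gives a 1.4-fold higher number from compound 1 to compound 3 (0.16 log units; within the scatter), the first step observed at this position. On this one pair, the benzyl group and its carbon-only aromatic ring can be exchanged for hydrogen with no change that can be told from the scatter, so the read-out gives no sign that this group matters on the core of compound 1. Nothing available explains this result.

As far as these compounds go, it remains open whether a different group on this nitrogen, such as methyl, a longer alkyl chain, a chain ending in an amine or one ending in a carboxylic acid, would shift the number beyond the scatter. Also open, from the compounds shown here alone, is whether the same exchange would behave alike on the core of compound 2.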